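Adding a ((tert-Butoxycarbonyl)oxy)methyl Group to Compound 3

This account rests on a few compounds, and the source may have more. Where it says the series, first, only, none or still open, it means among the compounds named here.

Three measured compounds share one core and differ only in the group on an oxygen next to a carbonyl group. Compound 1 `CC(C)OC(=O)OCOC(=O)C1=C(S[C@@H]2CN[C@H](C(=O)Nc3cccc(C(=O)O)c3)C2)[C@H](C)[C@@H]2[C@@H]([C@@H](C)O)C(=O)N12` carries an (isopropoxycarbonyl)oxy group there. In an ADME assay for metabolic stability, read by LC-MS, with a stated time of 3 h, at pH 6.5, tested at 50 uM (a higher number here means that more of the compound is left, a lower number that less of the compound is left), compound 1 gives > 95%, which is a limit of the assay rather than a number. Compound 2 `C[C@@H](O)[C@H]1C(=O)N2C(C(=O)OCC(F)(F)F)=C(S[C@@H]3CN[C@H](C(=O)Nc4cccc(C(=O)O)c4)C3)[C@H](C)[C@H]12` carries a trifluoromethyl instead. In this assay compound 2 gives > 95%, again a limit. Compound 3 `C[C@@H](O)[C@H]1C(=O)N2C(C(=O)OCOC(=O)OC(C)(C)C)=C(S[C@@H]3CN[C@H](C(=O)Nc4cccc(C(=O)O)c4)C3)[C@H](C)[C@H]12` carries a (tert-butoxycarbonyl)oxy group. In this assay compound 3 gives > 95%, also a limit.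

Because all three sit at the limit of > 95% in this assay, at which 3 of the 3 values shown sit, the steps between them cannot be read: a step that the two limits leave unreadable from compound 1 to compound 2, a step that the two limits leave unreadable from compound 1 to compound 3 and a step that the two limits leave unreadable from compound 2 to compound 3. Compound 3 therefore stands at the limit alongside the other two, with no number to set it apart.

Compound 4 `C[C@@H](O)[C@H]1C(=O)N2C(C(=O)OCOC(=O)OC(C)(C)C)=C(S[C@@H]3CN[C@H](C(=O)Nc4cccc(C(=O)OCOC(=O)OC(C)(C)C)c4)C3)[C@H](C)[C@H]12` differs from compound 3 by ((tert-butoxycarbonyl)oxy)methyl in place of hydrogen on an oxygen next to a carbonyl group. Within the data shown here, none of the measured steps bears on this change, and each of them is unreadable. The expectation for compound 4 rests on compound 3 giving > 95% in this assay, a limit. Compound 4 is therefore expected to remain at the limit, and the expected step of a number no higher from compound 3 to compound 4 (the limit leaves the size open) amounts to none beyond the scatter. The estimate for compound 4 in this assay is 95%, with a range from 85% to 99%.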

Compound 4, percent of the compound remaining: > 95%
Compound 4 ended at the assay's limit; the forecaster's own chance of this, stated with the estimate: 75%; the middle value sits exactly at the limit.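

In this assay compound 4 gives > 95%, which is a limit of the assay and not a number. No step between compound 4 and compound 1, compound 2 or compound 3 can be read, because all of them sit at one limit: the limit of > 95% in this assay, at which 4 of the 4 values shown sit.

The compounds shown leave open whether the percent of compound remaining differs among these four compounds at all.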